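This account rests on a few compounds, and the source may have more. Where it says the series, first, only, none or still open, it means among the compounds named here.

Measured compounds:
- compound 1 `COc1ccc(/C=C/C(=O)c2ccc(OC)c3c2OC(C)(C)C=C3)cc1OCCO`: 9600 nM in a functional assay on A-375 cells (Homo sapiens) for cytotoxicity, read by MTT assay; a higher number here means a weaker inhibitor, a lower number a stronger inhibitor
- compound 2 `COc1ccc(/C=C/C(=O)c2ccc(OC)c3c2OC(C)(C)C=C3)cc1OC(=O)C(C)C`: 310 nM in this assay
- compound 3 `COc1cccc(C(=O)Oc2cc(/C=C/C(=O)c3ccc(OC)c4c3OC(C)(C)C=C4)ccc2OC)c1`: 800 nM in this assay

Compound 1 stands at the highest number of the three, and so is the weakest inhibitor shown. Compound 4 `COc1ccc(/C=C/C(=O)Oc2cc(/C=C/C(=O)c3ccc(OC)c4c3OC(C)(C)C=C4)ccc2OC)cc1` differs from it in one place: (2-(4-methoxyphenyl)ethenyl)carbonyl in place of 2-hydroxyethyl on an oxygen on an aromatic ring. The two measured steps from compound 1 bear on this change, since each also replaces the 2-hydroxyethyl group with an acyl group on that oxygen. Both were large drops: a 31-fold lower number from compound 1 to compound 2 (1.49 log units; beyond the scatter) and a 12-fold lower number from compound 1 to compound 3 (1.08 log units; beyond the scatter). The aromatic acyl group in compound 3 gave the smaller drop, and compound 4 carries an aromatic acyl group too, so a drop of that order is expected: a 14-fold lower number from compound 1 to compound 4 (1.14 log units; beyond the scatter). Compound 4 is therefore estimated at 700 nM, with a likely range from 200 nM to 2500 nM.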

Compound 4, half-maximal inhibitory concentration: 2630 nM
Compound 4: middle estimate off by 3.8-fold (0.57 log units), on the low side, outside the stated range (above it).
By their numbers in this assay, from the lowest: compound 2; then compound 3; then compound 4; then compound 1.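

Acyl groups on this oxygen are not interchangeable in this assay: the change to (2-(4-methoxyphenyl)ethenyl)carbonyl gives only a 3.7-fold lower number from compound 1 to compound 4 (0.56 log units; beyond the scatter) and so keeps less of the gain seen with the other two acyl groups. The group on the carbonyl carbon alone moves the number, as shown by a 3.3-fold higher number from compound 3 to compound 4 (0.52 log units; beyond the scatter) and by an 8.5-fold higher number from compound 2 to compound 4 (0.93 log units; beyond the scatter) in the same way. Nothing measured here explains these differences. From the compounds shown here alone, how acetyl or a longer straight acyl chain on this oxygen would compare with isopropylcarbonyl stays open. So does the effect of an amine on such a chain.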